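Swapping a Piperidine Side Chain for a Benzyl Group

The source may report more compounds than this note shows. Statements on the series, on what has been measured and on what is new or still open speak of the compounds shown alone.

Compound 1, with the structure `CN(CCCN1CCCCC1)c1ccc(C(=O)N2CCc3ccc(OS(N)(=O)=O)cc3C2)cc1`, was tested in an assay on HEK293 cells for inhibition of Steryl-sulfatase (Homo sapiens), tested at 0.1 uM (a higher number here means a stronger effect of the compound at the concentration tested, a lower number a weaker effect), where it gives 17.4%. Two related compounds were measured alongside it. Compound 2, `CCN(Cc1ccccn1)c1cccc(C(=O)N2CCc3ccc(OS(N)(=O)=O)cc3C2)c1`, gives 6.5% in this assay, and compound 3, `CCN(Cc1ccccc1)Cc1ccc(S(=O)(=O)N2CCc3ccc(OS(N)(=O)=O)cc3C2)cc1`, gives 10%. Among these three numbers compound 1 carries the largest, but the gap to compound 3 lies within the usual scatter, so those two cannot be told apart, while the gap to compound 2 is beyond the scatter.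

The step of interest leads from compound 1 to compound 4, whose structure is `CCCN(Cc1ccccc1)c1ccc(C(=O)N2CCc3ccc(OS(N)(=O)=O)cc3C2)cc1` and which has not yet been measured in this assay. The change is benzyl(propyl)amino in place of methyl(3-(piperidin-1-yl)propyl)amino on an aromatic carbon

For the measured compounds named here, no pair of measured compounds differs in exactly this way, so the size of the step has to be judged from the three values themselves. All three fall in a low band, and compound 3, which also carries a benzyl group on a nitrogen, gives 10%, so no step beyond the scatter is expected in either direction. Compound 4 is therefore estimated to give 14%, within a range from 4% to 28%, which means an expected step of a number 3.4 percentage points lower from compound 1 to compound 4 (within the scatter).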

Compound 4, a percentage reported as inhibition, at one concentration (the size of the read-out at that concentration, not a potency): 64.8%
For compound 4 the middle estimate is 50.8 percentage points below the measured one, and the stated range ends below it.
By their numbers in this assay, from the lowest: compounds 2, 3 and 1 (each within the scatter of the next, the first and the last beyond it); then compound 4.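

In this assay, for the compounds shown here, benzyl(propyl)amino in place of methyl(3-(piperidin-1-yl)propyl)amino, on the aromatic carbon para to a large group, gives a number 47.4 percentage points higher from compound 1 to compound 4 (beyond the scatter), and compound 4 stands clear of the low band formed by the earlier compounds. This shows that the group at this position can strongly change the read-out, even though the group that leaves and the group that enters each have 11 heavy atoms, so the count of heavy atoms alone does not decide the result. The swap replaces a non-aromatic ring with an aromatic one of carbon only, removes one nitrogen and changes the chain on the amine nitrogen all at once, and no measurement here gives a reason for the large step.

The compounds shown do not separate the contribution of the benzyl group from that of the propyl chain or from the loss of the piperidine ring. A benzyl(methyl)amino group, a butyl chain in place of the propyl chain, or a fluorine on the benzyl ring would each test one of these parts on its own.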